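Where Compound 3 Stands and What Compound 4 May Bring

This account rests on a few compounds, and the source may have more. Where it says the series, first, only, none or still open, it means among the compounds named here.

Three compounds share a core carrying a sulfonamide and a chiral amine. Compound 1 `C[C@H](Nc1cc(F)c(S(=O)(=O)Nc2nccs2)cc1Cl)c1ccccc1` gives 20 nM in an assay on HEK293 cells for inhibition of SCN8A/SCN1B (Homo sapiens), read by patch clamp, with a stated time of 20 min; on this read-out lower numbers stand for stronger inhibition and higher numbers for weaker inhibition. Compound 2 `C[C@H](Nc1cc(F)c(S(=O)(=O)Nc2nccs2)cc1Cl)c1ccc(F)cc1` gives 230 nM in this assay, and compound 3 `C[C@H](Nc1cc(F)c(S(=O)(=O)Nc2cscn2)cc1Cl)c1ccccc1` gives 650 nM. Compound 3 thus holds the highest number of the three: the step of a 33-fold higher number from compound 1 to compound 3 (1.51 log units; beyond the scatter) is large and beyond the scatter, as is the step of a 12-fold higher number from compound 1 to compound 2 (1.06 log units; beyond the scatter).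

Compound 4 `C[C@H](Nc1cc(F)c(S(=O)(=O)Nc2cscn2)cc1Cl)c1cc(F)ccc1F` keeps the sulfonamide heterocycle of compound 3 and changes the aryl group on the amine: 2,5-difluorophenyl in place of phenyl on a saturated chain carbon bound to a nitrogen on an aromatic ring and a saturated chain carbon. For the measured compounds named here, no measured step shows exactly this change. Going by the values given here, the one step that bears on it is the fluoro-for-hydrogen exchange on the phenyl, where the number rose markedly from compound 1 to compound 2; compound 4 carries two fluorines on that ring, introduced alongside a different heterocycle, so the size of any effect is uncertain. On that basis compound 4 is expected to show a higher number than compound 3, with the step of a 3.1-fold higher number from compound 3 to compound 4 (0.49 log units; beyond the scatter) expected in this assay. Among the compounds with values here, compound 4 is therefore estimated at 2000 nM, within a range of 600 nM to 7000 nM, reflecting the single related step available.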

Compound 4, half-maximal inhibitory concentration: 119 nM
Compound 4: middle estimate off by 17-fold (1.23 log units), on the high side; the whole stated range lies above it.
By their numbers in this assay, from the lowest: compound 1; then compounds 4 and 2 (each within the scatter of the next); then compound 3.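

In this assay, exchanging phenyl for 2,5-difluorophenyl on the saturated chain carbon gives a 5.5-fold lower number from compound 3 to compound 4 (0.74 log units; beyond the scatter), a modest step but one beyond the scatter. This shows that fluorine on this aryl group does not push the number one way only: the earlier exchange, with the 1,3-thiazol-2-yl group on the sulfonamide nitrogen, gave a 12-fold higher number from compound 1 to compound 2 (1.06 log units; beyond the scatter), whereas this one, with the 1,3-thiazol-4-yl group there, runs in the opposite direction. The two steps differ both in the fluorine pattern on the ring and in the sulfonamide heterocycle, and no measurement offered here explains the reversal.

The compounds shown leave open whether the opposite directions follow from the fluorine pattern or from the heterocycle, a question that 2,5-difluorophenyl paired with the 1,3-thiazol-2-yl group on the sulfonamide nitrogen would address directly. They also leave open whether a methoxy group or a chlorine on the phenyl, in place of fluorine, would lower or raise the number in this assay.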